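Replacing the amide substituent of compound 3

This account rests on a few compounds, and the source may have more. Where it says the series, first, only, none or still open, it means among the compounds named here.

Of the compounds shown here, three sharing one core have been tested in a functional assay on EBC-1 cells (Homo sapiens) for antiproliferative activity, with a stated time of 72 h; on this read-out higher numbers stand for weaker inhibition and lower numbers for stronger inhibition. Compound 1 `N#Cc1cccc(-c2cc(F)c3ncc(Cc4ccc5ncccc5c4)n3c2)c1` gives 107 nM, and compound 2 `CNC(=O)c1cc(-c2cc(F)c3ncc(Cc4ccc5ncccc5c4)n3c2)ccc1F` gives 246 nM. Compound 3 `CN(C)CCNC(=O)c1ccc(-c2cc(F)c3ncc(Cc4ccc5ncccc5c4)n3c2)cc1F` gives 49 nM, the lowest number of the three, and its gaps to both others lie beyond the usual scatter. No two of these compounds differ in only one place, so no direct measure of a single change is available. Compound 4 `O=C(NC1CCOCC1)c1ccc(-c2cc(F)c3ncc(Cc4ccc5ncccc5c4)n3c2)cc1F` carries oxan-4-yl in place of 2-(dimethylamino)ethyl on an amide-type nitrogen. Of the tested compounds, only compound 3 carries 2-(dimethylamino)ethyl, and the two without it stand higher, compound 1 at 107 nM and compound 2 at 246 nM. This is thin support from three compounds, but it points towards weaker inhibition. In this assay the expected change is a rise somewhat beyond the scatter, estimated as a 2.4-fold higher number from compound 3 to compound 4 (0.39 log units; beyond the scatter). For compound 4 the estimated value is 120 nM, with an expected range from 40 nM to 350 nM.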

Compound 4, half-maximal inhibitory concentration: 70.5 nM
For compound 4 the middle estimate is 1.7-fold (0.23 log units) above the measured one; the measured number falls inside the stated range.
By their numbers in this assay, from the lowest: compounds 3, 4 and 1 (each within the scatter of the next, the first and the last beyond it); then compound 2.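

In this assay the change at this amide-type nitrogen reads a 1.4-fold higher number from compound 3 to compound 4 (0.16 log units; within the scatter) and gives the first direct measure of a single change in this series. The earlier compounds shown here could only hint that 2-(dimethylamino)ethyl mattered, whereas this step shows that oxan-4-yl, with its six-membered non-aromatic ring and an oxygen in place of the chain's nitrogen, cannot be told apart from it on this read-out, so the dimethylamino chain is not needed here to hold the number at this level. No supporting evidence bears on why the two groups read alike.

From the compounds shown here alone, whether a piperidin-4-yl ring, a 2-methoxyethyl chain or a carboxylic acid on the same nitrogen would read alike remains open. So does the role of the amide hydrogen, which a morpholine amide would test.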